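The source may report more compounds than this note shows. Statements on the series, on what has been measured and on what is new or still open speak of the compounds shown alone.

Of the compounds shown here, two have been tested in an ADME assay on H1-HeLa cells (Homo sapiens) for cytotoxicity, read by MTT assay, with a stated time of 3 days; a higher number here means that more compound is tolerated, a lower number that less compound is tolerated. Compound 1 `CNC(=O)c1cc(Oc2ccc3cc(C(=O)OC)sc3c2)ccn1` gives only a limit of the assay, > 100000 nM. Among the compounds with values here, compound 2 `CNC(=O)c1cc(Oc2ccc3c(C)c(C(=O)OC)sc3c2)ccn1` gives 10800 nM, the only true number measured so far. Within the data shown here, the one measured step, an at least 9.2-fold lower number from compound 1 to compound 2 (0.96 log units; beyond the scatter), concerns a methyl group and not the change now in question. Compound 3 `CCNC(=O)c1sc2cc(Oc3ccnc(C(=O)NC)c3)ccc2c1C` differs from compound 2 by ethylamino in place of methoxy on a carbonyl carbon. Among the measured compounds shown here, no measured step bears on an ethylamino in place of methoxy, so in this assay no change beyond the scatter is expected, a 1.3-fold higher number from compound 2 to compound 3 (0.11 log units; within the scatter). Compound 3 is estimated at 14000 nM, between 4000 nM and 60000 nM.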

Compound 3, half-maximal cytotoxic concentration: > 100000 nM
Compound 3: a limit, no number (the forecaster's own chance of this, stated with the estimate: 20%); middle value at least 7.1-fold (0.85 log units) from the limit.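

Ethylamino in place of methoxy on a carbonyl carbon gives an at least 9.2-fold higher number from compound 2 to compound 3 (0.96 log units; beyond the scatter), so in this assay this second place on the shared core also matters, not only the methyl change seen earlier. Compound 3 gives > 100000 nM, a limit and not a number. The step is therefore a lower bound, and its full size cannot be read: the limit of > 100000 nM in this assay, at which 2 of the 3 values shown sit.

Still open, from the compounds shown here alone, is whether the nitrogen or the longer chain carries this step. Methylamino, propylamino or a carboxylic acid on the same carbonyl carbon would help to separate the two.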